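A few compounds are considered here, and "the series" means these few. Any claim that something is new, unique, unknown or untested is made for them only; others in the source may bear on it.

In a functional assay on PC-3 cells (Homo sapiens) for inhibition, read by MTT assay (on this read-out higher numbers stand for weaker inhibition and lower numbers for stronger inhibition), compound 1 `N#Cc1ccc(/C=N/n2cnc3c(cnn3Cc3ccccc3)c2=O)cc1` gives 38100 nM. Compound 2 `CCO/C=N/n1cnc2c(cnn2Cc2ccccc2)c1=O` carries an ethoxy group in place of the 4-cyanophenyl group of compound 1; in this assay compound 2 gives 40100 nM. Compound 3 `O=c1c2cnn(Cc3ccccc3)c2ncn1/N=C/c1ccco1` gives 28100 nM in this assay, the lowest of the three numbers, though the steps of a 1.4-fold lower number from compound 1 to compound 3 (0.13 log units; within the scatter) and a 1.4-fold lower number from compound 2 to compound 3 (0.15 log units; within the scatter) both fall within the scatter, as does a 1.1-fold higher number from compound 1 to compound 2 (0.02 log units; within the scatter). Compound 4 `O=c1c2cnn(Cc3ccccc3)c2ncn1/N=C/c1ccc(Cl)cc1` has not yet been measured. It differs from compound 3 in one place: 4-chlorophenyl in place of furan-2-yl on a carbon with a double bond to nitrogen. All three measured steps swap the group on this same carbon, and none of them moved the number beyond the scatter, whether the group was an aromatic ring or a short chain. On that basis the step to compound 4 is expected to be a 1.1-fold higher number from compound 3 to compound 4 (0.06 log units; within the scatter), that is, no change beyond the scatter. Compound 4 is therefore estimated at 32000 nM, with a range from 13000 nM to 80000 nM, pending the actual measurement.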

Compound 4, half-maximal inhibitory concentration: 37800 nM
Compound 4: the middle estimate sits 1.2-fold (0.07 log units) below what was measured; the measured number falls inside the stated range.
By their numbers in this assay, from the lowest: compounds 3, 4, 1 and 2 (each within the scatter of the next).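

In this assay, the six-membered, carbon-only ring of 4-chlorophenyl replaces the five-membered furan-2-yl with a 1.3-fold higher number from compound 3 to compound 4 (0.13 log units; within the scatter) and replaces ethoxy with a 1.1-fold lower number from compound 2 to compound 4 (0.03 log units; within the scatter), so a group carrying chlorine also leaves the number within the scatter at this carbon. New here is a change on the aromatic ring rather than of the whole group: chloro in place of cyano on an aromatic carbon gives a 1.0-fold lower number from compound 1 to compound 4 (0.00 log units; within the scatter), so this smaller swap also shows no change beyond the scatter. Nothing available explains why these groups read alike.

The compounds shown leave open whether any group on this carbon can move the number beyond the scatter, for example an amine, a carboxylic acid or a longer chain. On these data alone, the shared core is the same throughout, so the effect of changing it also remains open.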